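Swapping One Group on a Weakly Active Compound

The source may report more compounds than this note shows. Statements on the series, on what has been measured and on what is new or still open speak of the compounds shown alone.

Measured in a functional assay on DU-145 cells (Homo sapiens) for antiproliferative activity, read by MTT assay, with a stated time of 24 h; on this read-out lower numbers stand for stronger inhibition and higher numbers for weaker inhibition:
Compound 1 `COc1ccc(-c2noc(C3CCCN3)n2)cc1OC1CCCC1`: 242000 nM
Compound 2 `Fc1ccc(-c2nc(-c3ccccc3)no2)cc1`: > 1000000 nM (a limit of the assay, not a number)
Compound 3 `COc1cc(-c2noc(-c3ccncc3)n2)ccc1OCc1ccccc1`: > 1000000 nM (a limit of the assay, not a number)

Compound 1 is the only one of the three with a true number, 242000 nM. The rest of the picture is the limit of > 1000000 nM in this assay, at which 2 of the 3 values shown sit, and such an entry marks the end of the assay's range rather than a measurement. Compound 1 therefore stands as the single measured point in the set, and nothing shown sets a lower number beside it.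

The next compound is compound 4 `COc1ccc(-c2noc(-c3ccc(O)cc3)n2)cc1OC1CCCC1`, which keeps the rest of compound 1 and exchanges one group: 4-hydroxyphenyl in place of pyrrolidin-2-yl on an aromatic carbon.

Among the measured compounds shown here, no two measured compounds differ in just one place, so the data give no direct size for a change like this. For the measured compounds named here, the only anchor is compound 1 at 242000 nM, and from it no shift beyond the scatter is expected in this assay, with a slight lean towards weaker inhibition. The estimated step is a 1.2-fold higher number from compound 1 to compound 4 (0.09 log units; within the scatter). A result at the limit of this assay would also be no surprise. For compound 4 the expected value is 300000 nM, with an estimated range from 50000 nM to 1000000 nM.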

Compound 4, half-maximal inhibitory concentration: 780 nM
Compound 4: middle estimate off by 380-fold (2.59 log units), on the high side; measured number below the stated range.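

In this assay, among the compounds shown here, the group at this place on the shared core turns out to have a very large effect, something the earlier compounds could not show because no two of them differed in just one place. Putting 4-hydroxyphenyl in place of pyrrolidin-2-yl gives a 310-fold lower number from compound 1 to compound 4 (2.49 log units; beyond the scatter), so a single exchange on a weakly active compound is enough to change the read-out dramatically. The two groups match in their counts of hydrogen-bond donors and acceptors and neither carries a net charge, so those counts do not separate them, and nothing measured here gives a reason for the size of the step.

What the compounds shown leave open is which part of the new group matters: the six-membered aromatic ring itself or the hydroxyl on it, a question that a plain phenyl or a methoxyphenyl group at the same place would help to answer. From the compounds shown here alone, it also remains open how an aminophenyl group, a carboxylic acid or a longer chain would read at this place, so this one large step cannot yet be stretched into a trend.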